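Swapping methoxy for chloro on the aryl imine of compound 1

The source may report more compounds than this note shows. Statements on the series, on what has been measured and on what is new or still open speak of the compounds shown alone.

Compound 1 `COc1cccc(/C=N/c2c(C)n(C)n(-c3ccccc3)c2=O)c1` carries the shared core with a 3-methoxyphenyl imine. In a functional assay on HCT-116 cells (Homo sapiens) for cytotoxicity, read by MTT assay, with a stated time of 72 h (on this read-out lower numbers stand for stronger inhibition and higher numbers for weaker inhibition), compound 1 gives 933000000 nM, the highest number of the three measured compounds. Compound 2 `COc1cc(/C=N/c2c(C)n(C)n(-c3ccccc3)c2=O)ccc1O` gives 468000000 nM, and compound 3 `COc1cccc(/C=N/c2c(C)n(C)n(-c3ccccc3)c2=O)c1O` gives 89100000 nM. Adding a hydroxy group gave a 2.0-fold lower number from compound 1 to compound 2 (0.30 log units; within the scatter) and a 10-fold lower number from compound 1 to compound 3 (1.02 log units; beyond the scatter). Compound 4 `Cc1c(/N=C/c2cccc(Cl)c2)c(=O)n(-c2ccccc2)n1C` differs from compound 1 by chloro in place of methoxy on an aromatic carbon. Neither measured step involves this kind of replacement, so the data give no direct guide; both only show that this ring position tolerates change. The expected step from compound 1 to compound 4 is therefore a 1.0-fold lower number from compound 1 to compound 4 (0.02 log units; within the scatter), no more than the scatter. Compound 4 is expected to give 900000000 nM, with a range from 250000000 nM to 3000000000 nM.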

Compound 4, half-maximal inhibitory concentration: 912000000 nM
Estimate against measurement, compound 4: 1.0-fold (0.01 log units) below; measured number inside the range.
By their numbers in this assay, from the lowest: compound 3; then compounds 2, 4 and 1 (each within the scatter of the next).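

Swapping the methoxy of the 3-methoxyphenyl for chloro gives a 1.0-fold lower number from compound 1 to compound 4 (0.01 log units; within the scatter) in this assay, so the number does not depend on the methoxy group at this position. The earlier steps shown here only added a hydroxy group and kept the methoxy, whereas this step removes it and leaves one heavy atom and no hydrogen-bond acceptor in its place. Nothing measured here offers an explanation for this result. Still open, going by these compounds, is whether an amine or a carboxylic acid at this position would behave like chloro. Also open, on these data alone, is whether chloro in place of the methoxy of compound 3 would keep that compound's lower number.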